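Half-life of compound 2 and its 4-methoxybenzyl analogue

The compounds below may be only part of what the source reports. "The series", "measured", "known", "first", "only" and "open" are said of these compounds alone.

Measured in an ADME assay (liver, Mus musculus) for metabolic stability, using microsomes; a lower number here means that the compound disappears faster, a higher number that the compound lasts longer:
Compound 1 `CC(C)N(C(=O)n1cnc(S[C@@H]2C[C@H]3CC[C@@H]2C3)n1)C(C)C`: < 0.0834 h, a limit of the assay and not a number
Compound 2 `CN(Cc1ccccc1)C(=O)n1cnc(S(=O)(=O)[C@@H]2C[C@H]3CC[C@@H]2C3)n1`: 0.323 h

Among the measured compounds shown here, compound 2 holds the only true number in this pair, 0.323 h. Compound 3 `COc1ccc(CN(C)C(=O)n2cnc(S(=O)(=O)[C@@H]3C[C@H]4CC[C@@H]3C4)n2)cc1` carries methoxy in place of hydrogen on an aromatic carbon, para to a large group, turning benzyl into 4-methoxybenzyl (methoxy in place of hydrogen on an aromatic carbon). For the measured compounds named here, no measured pair shows this change, so any size given for it remains an expectation. The expected 1.5-fold lower number from compound 2 to compound 3 (0.17 log units; within the scatter) is a small fall in this assay, close to the usual scatter. Compound 3 is estimated at 0.22 h, with an expected range of 0.1 h to 0.42 h.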

Compound 3, half-life: 0.377 h
The estimate for compound 3 lay 1.7-fold (0.23 log units) below the measured number, and the stated range covers the measured number.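

In this assay, among the compounds shown here, the first measured pair for this change gives a 1.2-fold higher number from compound 2 to compound 3 (0.07 log units; within the scatter) and so does not separate benzyl from 4-methoxybenzyl at this position. This one step is all that is known of the change, and it rests on a single pair sharing one core. Nothing given here accounts for the step.

From the compounds shown here alone, whether fluorine, a hydroxyl or an amine at the same place would also stay level with hydrogen remains open. So does whether methoxy would read the same on a different core.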